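Aryl swap on the chain carbon bound to aromatic nitrogen

A few compounds are considered here, and "the series" means these few. Any claim that something is new, unique, unknown or untested is made for them only; others in the source may bear on it.

Compound 1 `Cc1cc(Nc2ccn(Cc3cccc4ccccc34)n2)n2nc(SCc3ccc(Br)cc3)nc2n1` gives 5660 nM in a functional assay on PC-9 cells (Homo sapiens) for inhibition, read by MTT assay, with a stated time of 72 h (on this read-out lower numbers stand for stronger inhibition and higher numbers for weaker inhibition), the lowest of the two numbers at hand; compound 2 `Cc1cc(Nc2cc(-c3ccccc3)[nH]n2)n2nc(SCc3ccc(F)cc3)nc2n1` gives 8110 nM in this assay, a gap within the scatter. Compound 3 `C=CCSc1nc2nc(C)cc(Nc3cc(-c4ccccc4)[nH]n3)n2n1` reaches only the assay limit, > 50000 nM, in this assay. Going by the values given here, the single measured step, an at least 6.1-fold higher number from compound 2 to compound 3 (0.78 log units; beyond the scatter), concerns the group on the saturated chain carbon bound to a sulfur and sits at the limit of > 50000 nM in this assay, at which 1 of the 3 values shown sits. Compound 4 `Cc1cc(Nc2ccn(Cc3csc4ccc(Cl)cc34)n2)n2nc(SCc3ccc(Br)cc3)nc2n1` alters the other arm: 5-chloro-1-benzothiophen-3-yl in place of naphthalen-1-yl on a saturated chain carbon bound to an aromatic nitrogen. Among the compounds with values here, no measured step touches this position, so the expected step is a 1.0-fold lower number from compound 1 to compound 4 (0.01 log units; within the scatter), nothing beyond the scatter. Compound 4 is therefore estimated at 5500 nM, within 2000 nM to 15000 nM.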

Compound 4, half-maximal inhibitory concentration: 4350 nM
Estimate against measurement, compound 4: 1.3-fold (0.10 log units) above; the measured number falls inside the stated range.
By their numbers in this assay, from the lowest: compounds 4, 1 and 2 (each within the scatter of the next). At a limit, above all of these: compound 3.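

In this assay, the arm on a saturated chain carbon bound to an aromatic nitrogen now has a measured step: a 1.3-fold lower number from compound 1 to compound 4 (0.11 log units; within the scatter). This position therefore accepts 5-chloro-1-benzothiophen-3-yl in place of naphthalen-1-yl, with one five-membered aromatic ring, a sulfur and a chlorine entering, and the number stays within the scatter. The data at hand give no explanation for this tolerance.

Both groups at this position are fused aromatic pairs of rings, so the tolerance is shown only for that kind of group. On these data alone, whether a plain phenyl, a morpholine or a carboxylic acid on the same chain carbon would hold the number remains open.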